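The source may hold more compounds than are shown below. What is called first, only, known or untested is meant among the compounds shown, and "the series" means these compounds.

In a functional assay on KMS-11 cells (Homo sapiens) for antiproliferative activity, read by CellTiter-Glo, with a stated time of 72 h (on this read-out higher numbers stand for weaker inhibition and lower numbers for stronger inhibition), compound 1 `COc1ccc(C(=O)N(Cc2ccncc2)Cc2cccc(OCCc3ccc(C)cc3)c2)cc1` gives 9100 nM and compound 2 `COc1ccc(C(=O)N(Cc2ccncc2)Cc2cccc(OCCc3cccc(C(F)(F)F)c3)c2)cc1` gives 8900 nM while compound 3 `COc1ccc(C(=O)N(Cc2ccncc2)Cc2cccc(OCc3ccc(C(F)(F)F)cc3)c2)cc1` gives 14300 nM in the same test. Compound 3 thus sits within the scatter of both others. Compound 4 `COc1ccc(C(=O)N(Cc2ccncc2)Cc2cccc(OCc3ccc(F)cc3)c2)cc1` differs from compound 3 at one place: fluoro in place of trifluoromethyl on an aromatic carbon with fluoro in place of trifluoromethyl on an aromatic carbon, para to a large group. Among the measured compounds shown here, no measured step isolates this change. The closest evidence is a 1.6-fold higher number from compound 1 to compound 3 (0.20 log units; within the scatter) and a 1.6-fold higher number from compound 2 to compound 3 (0.21 log units; within the scatter) and both alter that same aryl end without leaving the scatter. No step beyond the scatter is therefore expected in this assay here. The expected change is a 1.2-fold lower number from compound 3 to compound 4 (0.08 log units; within the scatter) in this estimate. Compound 4 is estimated at 12000 nM with an expected range from 6000 nM to 24000 nM in all.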

Compound 4, half-maximal inhibitory concentration: 22700 nM
Beside the measured number, compound 4's estimate is 1.9-fold (0.28 log units) below it; measured number inside the range.
By their numbers in this assay, from the lowest: compounds 2, 1, 3 and 4 (each within the scatter of the next, the first and the last beyond it).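

In this assay, fluoro in place of trifluoromethyl on this aromatic carbon, para to a large group, gives a 1.6-fold higher number from compound 3 to compound 4 (0.20 log units; within the scatter), so this change alone stays within the scatter. Unlike the earlier steps at this aryl end, the comparisons with the other two compounds pass beyond the scatter, though only modestly, with a 2.6-fold higher number from compound 2 to compound 4 (0.41 log units; beyond the scatter) and a 2.5-fold higher number from compound 1 to compound 4 (0.40 log units; beyond the scatter). No measurement offered here accounts for these steps. The compounds shown leave open whether an amine or a carboxylic acid on this aromatic carbon would move the number beyond the scatter of compound 3 . They also leave open how a longer chain would read with the 4-fluorophenyl end.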